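Carbamate series: methyl to hydrogen on an aromatic carbon

The source may report more compounds than this note shows. Statements on the series, on what has been measured and on what is new or still open speak of the compounds shown alone.

Measured so far in this series:
compound 1 `CCCCOC(=O)Nc1ccc([Se]C#N)cc1` gives 59700 nM
compound 2 `CC(C)COC(=O)Nc1ccc([Se]C#N)cc1` gives 73000 nM
compound 3 `Cc1ccc(OC(=O)Nc2ccc([Se]C#N)cc2)cc1` gives 69800 nM

In a functional assay on MCF7 cells (Homo sapiens) for cytotoxicity, read by MTT assay, with a stated time of 72 h (a lower number here means that less compound is tolerated, a higher number that more compound is tolerated), compound 3 stands second highest of the three numbers. Its nearest neighbour is compound 2, which gives 73000 nM; the furthest is compound 1, which gives 59700 nM. All three values sit within the scatter of one another, so no order among them is claimed. Within the data shown here, the single step between compounds that differ in one place, a 1.2-fold higher number from compound 1 to compound 2 (0.09 log units; within the scatter), concerns the saturated chain bound to the oxygen and lies within the scatter.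

Compound 4 `N#C[Se]c1ccc(NC(=O)Oc2ccccc2)cc1` differs from compound 3 by hydrogen in place of methyl on an aromatic carbon. Among the measured compounds shown here, no measured step bears directly on this change: the step from compound 1 to compound 2 touches the chain on oxygen, not the aromatic ring, and compound 3 has no measured partner differing only at that aromatic carbon. The values of compounds 1, 2 and 3 show that the group on oxygen has so far moved the number only within the scatter.

The expected step from compound 3 to compound 4 is therefore a 1.1-fold lower number from compound 3 to compound 4 (0.02 log units; within the scatter), i.e. none beyond the scatter. Compound 4 is estimated at 66000 nM, with a range of 35000 nM to 125000 nM.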

Compound 4, concentration lethal to 50% of the cells: 67800 nM
The estimate for compound 4 lay 1.0-fold (0.01 log units) below the measured number; the range from low to high includes it.
By their numbers in this assay, from the lowest: compounds 1, 4, 3 and 2 (each within the scatter of the next).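

In this assay, among these compounds, the first measured step on the aromatic ring, at the carbon para to a large group, is a 1.0-fold lower number from compound 3 to compound 4 (0.01 log units; within the scatter), so hydrogen and methyl cannot be told apart at this position. Compound 4 also extends the comparison of groups on oxygen to an unsubstituted phenyl, with a 1.1-fold lower number from compound 2 to compound 4 (0.03 log units; within the scatter) for phenyl in place of isobutyl and a 1.1-fold higher number from compound 1 to compound 4 (0.06 log units; within the scatter) for phenyl in place of butyl, so neither exchange of a saturated chain for phenyl separates the compounds. No measurement at hand offers an explanation for these small steps.

Going by these compounds, whether a group other than methyl on this aromatic carbon, such as an amine or a carboxylic acid, or a much longer chain on oxygen would give a step beyond the scatter remains open. On these data alone, all four compounds share the core, so it also remains open how far the number in this assay depends on that core, for example on the nitrile bound to selenium.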